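Swapping the aryl group on compound 1

The compounds below may be only part of what the source reports. "The series", "measured", "known", "first", "only" and "open" are said of these compounds alone.

- compound 1 `COc1ccc(F)cc1N1C(=O)CSC1c1cccc(C(=O)NCCCCn2cccn2)c1`: 50000 nM
- compound 2 `COc1ccc(F)cc1N1C(=O)CSC1c1cccc(C(=O)NCCCCc2ccccc2)c1`: 10000 nM
- compound 3 `Cc1cccc(N2C(=O)CSC2c2cccc(C(=O)NCCCCc3ccccc3)c2)c1`: 10000 nM

All three values come from a physicochemical assay for solubility, read by turbidimetry, measured as kinetic solubility, at pH 6.8; a lower number here means a less soluble compound, a higher number a more soluble compound. Compound 1 has the highest number of the three. Compound 4 `Cc1ccnc(N2C(=O)CSC2c2cccc(C(=O)NCCCCn3cccn3)c2)c1` has not been measured yet. It keeps the 1H-pyrazol-1-yl chain of compound 1 and differs in one place, where 4-methylpyridin-2-yl stands in place of 5-fluoro-2-methoxyphenyl on an amide-type nitrogen in a ring: 4-methylpyridin-2-yl in place of 5-fluoro-2-methoxyphenyl on an amide-type nitrogen in a ring.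

Two measured steps can be weighed here. The first, a 5.0-fold lower number from compound 1 to compound 2 (0.70 log units; beyond the scatter), is a change at the far end of the chain, so it does not touch the place that changes now. The second, no change at the digits printed from compound 2 to compound 3 (within the scatter), is a swap at the same place and is the closer guide. It is only a partial guide, since it was measured with phenyl on the chain and the entering ring there has carbon only. Among the measured compounds shown here, no measured compound has a ring with a hetero atom at this place.

On that evidence, no step beyond the scatter is expected in this assay, and the estimated step is a 1.1-fold higher number from compound 1 to compound 4 (0.04 log units; within the scatter). Compound 4 is expected at 55000 nM, within an estimated range of 22000 nM to 120000 nM.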

Compound 4, solubility: 50000 nM
For compound 4 the middle estimate is 1.1-fold (0.04 log units) above the measured one; the measured number falls inside the stated range.
By their numbers in this assay, from the lowest: compounds 2 and 3 (each within the scatter of the next); then compounds 1 and 4 (each within the scatter of the next).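

In this assay, replacing 5-fluoro-2-methoxyphenyl with 4-methylpyridin-2-yl on the amide-type nitrogen in a ring gives no change at the digits printed from compound 1 to compound 4 (within the scatter), so this swap leaves the reading within the scatter when the 1H-pyrazol-1-yl chain is present. This adds two things to the earlier swap at this place, which gave no change at the digits printed from compound 2 to compound 3 (within the scatter) with phenyl on the chain: the place has now been tested with a second chain end, and the entering ring now has a hetero atom, whereas the earlier entering ring had carbon only. Across these two swaps, the only two shown at this place, neither reading moves beyond the scatter, and nothing measured alongside these compounds offers an explanation for that.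

The compounds shown leave open whether the step seen at the far end of the chain, where phenyl replaced 1H-pyrazol-1-yl, would also appear with 4-methylpyridin-2-yl on the ring nitrogen. They also leave open whether this place would stay as tolerant of change with a ring carrying an amine or a carboxylic acid.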